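A drawn stereocentre in the chain of compound 2

The compounds below may be only part of what the source reports. "The series", "measured", "known", "first", "only" and "open" are said of these compounds alone.

In a functional assay on SW480 cells (Homo sapiens) for antiproliferative activity, read by MTT assay, with a stated time of 48 h (on this read-out higher numbers stand for weaker inhibition and lower numbers for stronger inhibition), compound 1 (`CCCCCCCCC[C@H](CCOS(C)(=O)=O)n1cnc2c(Cl)ncnc21`) gives 9720 nM and compound 2 (`CCCCCCCCCC(CCN=[N+]=[N-])n1cnc2c(Cl)ncnc21`) gives 1200 nM. Compound 2 holds the lower of the two numbers, and its gap to compound 1 lies beyond the scatter. Compound 3 (`CCCCCCCCC[C@H](CCN=[N+]=[N-])n1cnc2c(Cl)ncnc21`) is still to be measured and differs from compound 2 as follows: the two compounds have the same atoms and bonds; at least one stereo element is drawn with a configuration in one of them and without one in the other: 1 of 2 stereo elements differ; a stereocentre at a saturated chain carbon is drawn without a configuration in compound 2 and R in compound 3. The stereocentre at a saturated chain carbon is drawn without a configuration in compound 2 and R in compound 3. Among the compounds with values here, no measured pair shows a change of this kind, so the only anchor is compound 2 at 1200 nM. In this assay, no step beyond the scatter is expected, and no direction is favoured. The expected 1.1-fold lower number from compound 2 to compound 3 (0.04 log units; within the scatter) is therefore small. Compound 3 is estimated at 1100 nM, with an expected range from 500 nM to 2400 nM.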

Compound 3, half-maximal inhibitory concentration: 1220 nM
Estimate against measurement, compound 3: 1.1-fold (0.04 log units) below, and the stated range covers the measured number.
By their numbers in this assay, from the lowest: compounds 2 and 3 (each within the scatter of the next); then compound 1.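

In this assay, within the data shown here, defining the chain stereocentre as R leaves no step that can be read: a 1.0-fold higher number from compound 2 to compound 3 (0.01 log units; within the scatter). Compound 3 also carries the same drawn configuration as compound 1, so the exchange of (methylsulfonyl)oxy for azido now stands alone as the single difference, and it gives an 8.0-fold lower number from compound 1 to compound 3 (0.90 log units; beyond the scatter). What the first of these steps says about configuration is limited, because the comparison rests on a drawing and not on two defined forms: the fact that one of compounds 2 and 3 is drawn with a defined configuration and the other without, at the place where they differ

The compounds shown leave open how the S configuration at this chain carbon would read, since only R and an undefined drawing appear here. They also leave open whether an amine or a carboxylic acid in place of azido, on the saturated chain carbon three bonds along the chain from an aromatic nitrogen, would hold the number of compound 3.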